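The compounds below may be only part of what the source reports. "The series", "measured", "known", "first", "only" and "open" are said of these compounds alone.

Measured compounds:
- compound 1, `CC(C)[C@@H](C[C@H]1SC(=O)NC1=O)c1ccc(-c2ccc3cccc(F)c3c2)[nH]c1=O`: 25.5 10^-6 cm/s
- compound 2, `CC(C)C(c1ccc(-c2ccc3cccc(F)c3c2)[nH]c1=O)C1C(=O)NC(=O)N1C`: "not determined" (no result reported)
- compound 3, `CC(C)C(c1ccc(-c2ccc3cccc(F)c3c2)[nH]c1=O)C1SC(=O)NC1=O`: 26.3 10^-6 cm/s

Three compounds sharing one core have been examined in an ADME assay on MDCK cells (Canis lupus familiaris) for permeability, in the apical to basolateral direction (a lower number here means that the compound crosses the layer more slowly, a higher number that the compound crosses the layer faster), which measures how quickly a compound crosses a cell layer from the apical to the basolateral side. In this assay compound 1 gives 25.5 10^-6 cm/s, and compound 3 gives 26.3 10^-6 cm/s. Compound 2 was entered but no number was reported for it. Compound 3 therefore stands highest of the two numbers available, yet its nearest neighbour, compound 1, lies within the scatter of the method, so the two are indistinguishable on this read-out.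

Compound 4, `CC(C)C(/C=C1\NC(=O)NC1=O)c1ccc(-c2ccc3cccc(F)c3c2)[nH]c1=O`, has not yet been measured. It differs from compound 3 as follows: a group of 8 heavy atoms (4 carbon, 2 nitrogen, 2 oxygen; one five-membered non-aromatic ring with 2 hetero atoms) in place of a group of 7 heavy atoms (3 carbon, 1 nitrogen, 2 oxygen, 1 sulfur; one five-membered non-aromatic ring with 2 hetero atoms), on a saturated chain carbon bound to an aromatic carbon and a saturated chain carbon. Among the compounds with values here, no step between two measured compounds covers a change of this kind, so the expectation rests on the single value of compound 3. The group entering carries one more hydrogen-bond donor than the group leaving, and on that basis a modest decrease is expected, likely within the scatter. The step of a 1.5-fold lower number from compound 3 to compound 4 (0.16 log units; within the scatter) is the estimated change. Compound 4 is expected to give 18 10^-6 cm/s, with a range from 8 10^-6 cm/s to 35 10^-6 cm/s.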

Compound 4, apparent permeability: 12.3 10^-6 cm/s
For compound 4 the middle estimate is 1.5-fold (0.17 log units) above the measured one; measured number inside the range.
By their numbers in this assay, from the lowest: compound 4; then compounds 1 and 3 (each within the scatter of the next).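

Within the data shown here, at the saturated chain carbon bound to an aromatic carbon and a saturated chain carbon, replacing the 2,4-dioxo-1,3-thiazolidin-5-yl group with the sulfur-free group of 8 heavy atoms gives a 2.1-fold lower number from compound 3 to compound 4 (0.33 log units; beyond the scatter) in this assay and is the only step available here. Among these compounds, the earlier compounds offered no step, so this is the first sign that the number responds to the group at this place, though the change is modest. No measurement shown here explains the difference.

The exchange alters the ring atoms, the double bonds outside aromatic rings and the hydrogen-bond donors and acceptors together, so the compounds shown do not separate which of these goes with the lower number. They also leave open what a carboxylic acid or an amine at this place would give.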